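The source may hold more compounds than are shown below. What is called first, only, known or untested is meant among the compounds shown, and "the series" means these compounds.

Notes on the series, next step.

Of the compounds shown here, two of the shared core have been measured. Compound 1 `CCO/C(O)=C1\C(COCCNC(=O)NCCN2CCNC2=O)=NC(C)=C(C(=O)OC)C1c1ccccc1Cl` gives 15.9 nM in a functional assay (aorta) with Rattus norvegicus as the target; a higher number here means a weaker inhibitor, a lower number a stronger inhibitor. Compound 2 `CCO/C(O)=C1\C(COCCN(C)S(N)(=O)=O)=NC(C)=C(C(=O)OC)C1c1ccccc1Cl` gives 25.1 nM in this assay. Within the data shown here, the only step between measured compounds, a 1.6-fold higher number from compound 1 to compound 2 (0.20 log units; within the scatter), stays within the scatter, so compound 2 and compound 1 are not ordered by these two numbers; compound 2 simply carries the higher of the two.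

Compound 3 `CCO/C(O)=C1\C(COCC/N=C(\NC#N)NCCN(C)C)=NC(C)=C(C(=O)OC)C1c1ccccc1Cl` is the next member, not yet measured. It differs from compound 2 in one place: a group of 11 heavy atoms (6 carbon, 5 nitrogen; no ring) in place of a group of 6 heavy atoms (1 carbon, 2 nitrogen, 2 oxygen, 1 sulfur; no ring), on a saturated chain carbon, two bonds along the chain from an oxygen on a saturated carbon

Among the measured compounds shown here, the one measured step bears on this change only loosely: it exchanged groups at the same place on the saturated chain carbon and left this assay essentially unmoved. For the measured compounds named here, the change to compound 3 is larger in atoms than that exchange, and no measured pair tests a group of this kind. On the evidence available, the step from compound 2 to compound 3 is expected to stay within the scatter, a 1.1-fold lower number from compound 2 to compound 3 (0.06 log units; within the scatter). Compound 3 is therefore estimated at 22 nM in this assay, with a range from 8 nM to 60 nM.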

Compound 3, half-maximal inhibitory concentration: 50.1 nM
Estimate against measurement, compound 3: 2.3-fold (0.36 log units) below; the measured number falls inside the stated range.
By their numbers in this assay, from the lowest: compounds 1, 2 and 3 (each within the scatter of the next, the first and the last beyond it).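

Among these compounds, at the saturated chain carbon, two bonds along the chain from an oxygen on a saturated carbon, the group of 11 heavy atoms in compound 3 gives the first step in this assay that passes the scatter, a 3.2-fold higher number from compound 1 to compound 3 (0.50 log units; beyond the scatter), while a 2.0-fold higher number from compound 2 to compound 3 (0.30 log units; within the scatter) stays within it, so compound 3 is separated from compound 1 but not from compound 2. The position is thus not indifferent to the group it carries, though heavy-atom count does not sort these results: the group in compound 1 and the group of 11 heavy atoms in compound 3 are close in size yet lie beyond the scatter of each other, while the group of 6 heavy atoms in compound 2 is separated from neither. No measurement available here bears on the origin of this separation.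

Among the compounds shown here, with only three groups at this place, and each differing from the others in several features at once, the part of the group in compound 3 that accounts for its step from compound 1 stays unresolved. A plain primary amine or a carboxylic acid at the same place would show how far a much smaller group moves the number in this assay.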